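Replacing Methoxy with (Methanesulfonamido)methyl in Compound 2

The source may report more compounds than this note shows. Statements on the series, on what has been measured and on what is new or still open speak of the compounds shown alone.

In a functional assay on A2780 cells (Homo sapiens) for antiproliferative activity, read by resazurin assay, with a stated time of 72 h (a higher number here means a weaker inhibitor, a lower number a stronger inhibitor), compound 1 `CN(Cc1ccccc1)C(=O)c1cc2c(Cc3cccc(Cl)c3)n[nH]c2cc1O` gives 410 nM and compound 2 `COc1ccc(CN(C)C(=O)c2cc3c(Cc4cccc(Cl)c4)n[nH]c3cc2O)cc1` gives 390 nM. For the measured compounds named here, these two values lie within the scatter of each other, so compound 2 stands level with the only other measured compound. Compound 3 `CN(Cc1ccc(CNS(C)(=O)=O)cc1)C(=O)c1cc2c(Cc3cccc(Cl)c3)n[nH]c2cc1O` carries (methanesulfonamido)methyl in place of methoxy on an aromatic carbon, para to a large group: (methanesulfonamido)methyl in place of methoxy on an aromatic carbon. Going by the values given here, the only measured step at this place is the arrival of methoxy in place of hydrogen, a 1.1-fold lower number from compound 1 to compound 2 (0.02 log units; within the scatter), and it stays within the scatter. Among the compounds with values here, that single step shows no sensitivity in this assay to the change made there, but no measurement yet covers the entering group. An expected change of a 1.3-fold higher number from compound 2 to compound 3 (0.11 log units; within the scatter) is therefore estimated, with no step beyond the scatter anticipated. Compound 3 is expected at 500 nM, with an estimated range of 170 nM to 1500 nM.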

Compound 3, half-maximal inhibitory concentration: 570 nM
Estimate against measurement, compound 3: 1.1-fold (0.06 log units) below; the measured number falls inside the stated range.
By their numbers in this assay, from the lowest: compounds 2, 1 and 3 (each within the scatter of the next).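

In this assay, the aromatic carbon para to a large group now also carries (methanesulfonamido)methyl, with 6 heavy atoms and 1 hydrogen-bond donor, and the result is a 1.5-fold higher number from compound 2 to compound 3 (0.16 log units; within the scatter) and so no separation from the methoxy compound. Set against hydrogen at the same place, the group gives a 1.4-fold higher number from compound 1 to compound 3 (0.14 log units; within the scatter) and again stays within the scatter. Hydrogen, methoxy and (methanesulfonamido)methyl thus give values that cannot be told apart here, which extends the earlier result from a small group to one that brings a sulfonamide and a hydrogen-bond donor.

Going by these compounds, whether an amine, a carboxylic acid or a longer chain at this place would give a step beyond the scatter remains open. No measurement shown bears on why these three values stay together.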